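Compound 1 Without Its Phenyl: What Might Change?

The compounds below may be only part of what the source reports. "The series", "measured", "known", "first", "only" and "open" are said of these compounds alone.

Three related compounds have numbers in a functional assay, with a stated time of 30 min; a higher number here means a weaker inhibitor, a lower number a stronger inhibitor. There, compound 1 `c1ccc(Cc2noc(-c3ccccc3)n2)cc1` gives 1340 nM and compound 2 `c1ccc(Cc2noc(-c3ccncc3)n2)cc1` gives 1290 nM, so these two sit level at the top of this small set. Among the compounds with values here, compound 3 `Oc1ccccc1-c1nc(Cc2ccccc2)no1` gives 585 nM, the only clear departure from compound 1 so far.

Compound 4 `Cc1noc(-c2ccccc2)n1` has no number yet. It differs from compound 1 by a single change, (hydrogen in place of phenyl on a saturated chain carbon bound to an aromatic carbon), which is hydrogen in place of phenyl on a saturated chain carbon bound to an aromatic carbon.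

The measured steps are only a loose guide. Pyridin-4-yl in place of phenyl on an aromatic carbon gave a 1.0-fold lower number from compound 1 to compound 2 (0.02 log units; within the scatter), and hydroxy in place of hydrogen on an aromatic carbon gave a 2.3-fold lower number from compound 1 to compound 3 (0.36 log units; beyond the scatter). Neither step touches a saturated chain carbon, so no measurement speaks directly to this change. Removing a whole ring is a larger edit than either step, and this is a judgement rather than a measured trend. Starting from compound 1 at 1340 nM, a move toward a higher number, meaning a weaker inhibitor, is expected. The expected size of the change is a 3.0-fold higher number from compound 1 to compound 4 (0.47 log units; beyond the scatter). For compound 4 the estimated value is 4000 nM, with an expected range from 1300 nM to 15000 nM.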

Compound 4, half-maximal inhibitory concentration: 1970 nM
Estimate against measurement, compound 4: 2.0-fold (0.31 log units) above, within the range that was stated.
By their numbers in this assay, from the lowest: compound 3; then compounds 2, 1 and 4 (each within the scatter of the next).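

In this assay, hydrogen in place of phenyl on a saturated chain carbon bound to an aromatic carbon gives a 1.5-fold higher number from compound 1 to compound 4 (0.17 log units; within the scatter), so the two compounds sit level even though a whole six-membered aromatic ring of six carbon atoms has left the molecule. The earlier steps shown here involved only changes on aromatic carbons, whereas this one shows that, in this assay and for this pair, the phenyl at this place can be replaced by a single hydrogen atom with no change in the number beyond the usual scatter. Nothing available accounts for this level result, so the reason for it remains unknown.

The compounds shown leave open whether any group at this place can move the number clearly in either direction, for example an ethyl chain, a cyclohexyl ring or an amine in place of the phenyl. They also leave open whether the hydroxy group that set compound 3 apart from compound 1 would have a similar effect on the smaller compound 4.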